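The compounds below may be only part of what the source reports. "The series", "measured", "known", "first", "only" and "open" are said of these compounds alone.

In a functional assay on 3T3-L1 cells (Mus musculus) for inhibition, with a stated time of 20 min (a higher number here means a weaker inhibitor, a lower number a stronger inhibitor), compound 3 (`CC(=O)N(Cc1cccc(F)c1F)Cc1cn(S(=O)(=O)c2ccc(F)cc2)c2ccccc12`) gives 10600 nM. That lies within the scatter of compound 1 (`CC(=O)N(Cc1cn(Cc2cccc(F)c2F)nn1)Cc1cn(S(=O)(=O)c2ccc(C)cc2)c2ccccc12`) at 9100 nM. Compound 2 (`Cc1ccc(S(=O)(=O)n2cc(CNCc3cccc(F)c3F)c3ccccc32)cc1`) gives 30000 nM. Its number is higher than that of compound 3, and this gap lies beyond the scatter. Compound 4 (`CC(=O)N(Cc1cccc(F)c1F)Cc1cn(S(=O)(=O)c2ccc(C)cc2)c2ccccc12`) has no value yet. It differs from compound 3 by a single exchange, methyl in place of fluoro on an aromatic carbon, para to a large group. Within the data shown here, no measured pair isolates this change, so no step beyond the scatter is expected, in either direction. Compound 1, which also carries (4-methylphenyl)sulfonyl, gives 9100 nM. The expected step of a 1.1-fold lower number from compound 3 to compound 4 (0.03 log units; within the scatter) is small. Compound 4 is estimated at 10000 nM, with a range of 4500 nM to 22000 nM.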

Compound 4, half-maximal inhibitory concentration: 17500 nM
For compound 4 the middle estimate is 1.8-fold (0.24 log units) below the measured one; measured number inside the range.
By their numbers in this assay, from the lowest: compounds 1, 3, 4 and 2 (each within the scatter of the next, the first and the last beyond it).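

Methyl in place of fluoro on an aromatic carbon, para to a large group, now has a measured step in this assay (a 1.7-fold higher number from compound 3 to compound 4 (0.22 log units; within the scatter)), and it stays within the scatter. On the amine nitrogen, acetyl in place of hydrogen (a 1.7-fold lower number from compound 2 to compound 4 (0.23 log units; within the scatter)) also stays within the scatter, so neither single exchange separates these compounds.

On these data alone, whether an amine or a carboxylic acid at this aromatic carbon would give a step beyond the scatter remains open. No measurement offered here explains either step.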